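A Phenyl Ring Replaces Hydrogen on the Chain of Compound 1

The source may hold more compounds than are shown below. What is called first, only, known or untested is meant among the compounds shown, and "the series" means these compounds.

Compound 1 `Cn1nc(-c2cccnc2)c2ccccc2c1=O` is the reference point of this series. Among the measured compounds shown here, in a functional assay (trachea) with Cavia porcellus as the target (on this read-out higher numbers stand for weaker inhibition and lower numbers for stronger inhibition), compound 1 gives 11500 nM, the highest number among the three compounds measured so far. Compound 2 `CCn1nc(-c2cccnc2)c2ccccc2c1=O` gives 1320 nM in this assay, and compound 3 `O=c1c2ccccc2c(-c2cccnc2)nn1CC1CCCCC1` gives 209 nM. The measured steps all run in one direction: an 8.7-fold lower number from compound 1 to compound 2 (0.94 log units; beyond the scatter), a 55-fold lower number from compound 1 to compound 3 (1.74 log units; beyond the scatter), and a 6.3-fold lower number from compound 2 to compound 3 (0.80 log units; beyond the scatter).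

Compound 4 `O=c1c2ccccc2c(-c2cccnc2)nn1Cc1ccccc1` carries a single change relative to compound 1: phenyl in place of hydrogen on a saturated chain carbon bound to an aromatic nitrogen. The two steps that start from compound 1 both bear on it, since each puts a carbon group on the same saturated chain carbon bound to an aromatic nitrogen, and the larger group, cyclohexyl, gave the larger step. Phenyl, a six-membered ring of carbon only, is the closer match to cyclohexyl than to methyl, so a large downward step is expected rather than a modest one. Compound 4 is therefore expected to show a 33-fold lower number from compound 1 to compound 4 (1.52 log units; beyond the scatter). The estimate for compound 4 in this assay is 350 nM, with a range from 100 nM to 1200 nM.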

Compound 4, half-maximal inhibitory concentration: 2450 nM
The estimate for compound 4 lay 7.0-fold (0.85 log units) below the measured number; measured number outside the range, above it.
By their numbers in this assay, from the lowest: compound 3; then compounds 2 and 4 (each within the scatter of the next); then compound 1.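

The result shows that a ring on this saturated chain carbon bound to an aromatic nitrogen does not by itself give a large step: phenyl in compound 4 lowers the number only modestly (a 4.7-fold lower number from compound 1 to compound 4 (0.67 log units; beyond the scatter)). The two six-membered rings are also clearly separated (a 12-fold higher number from compound 3 to compound 4 (1.07 log units; beyond the scatter)), so the kind of ring matters here, and not only its presence. Phenyl and methyl, by contrast, cannot be told apart (a 1.9-fold higher number from compound 2 to compound 4 (0.27 log units; within the scatter)), which makes compound 4 the exception to the trend seen in compounds 1, 2 and 3, where the larger group gave the lower number.

Nothing shown here explains why the phenyl and cyclohexyl rings differ. On these data alone, it also remains open whether a longer chain such as butyl, or a cyclohexyl ring carrying an amine, would track compound 3 or compound 4.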